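From 5-Chlorothiophen-2-yl to 4-Chloro-3-(trifluoromethyl)phenyl

The source may report more compounds than this note shows. Statements on the series, on what has been measured and on what is new or still open speak of the compounds shown alone.

Of the compounds shown here, three sharing one core have been measured in an ADME assay on HEK293 cells (Homo sapiens) for cytotoxicity, read by resazurin assay, with a stated time of 48 h; on this read-out lower numbers stand for higher toxicity in this test and higher numbers for lower toxicity in this test. Compound 1 `O=S(=O)(Nc1ccc(-c2nc3cc(NS(=O)(=O)c4ccc(Cl)s4)ccc3o2)cc1)c1ccc(Cl)s1` gives 41000 nM, the highest of the three numbers. Compound 2 `O=S(=O)(Nc1ccc(-c2nc3cc(NS(=O)(=O)c4ccc(Br)cc4)ccc3o2)cc1)c1ccc(Br)cc1` gives 22000 nM, which sits within the scatter of the number for compound 1, so the two cannot be told apart. Compound 3 `COc1ccc(S(=O)(=O)Nc2ccc3oc(-c4ccc(NS(=O)(=O)c5cc(Br)ccc5OC)cc4)nc3c2)cc1` gives 18000 nM, a number that lies beyond the scatter below that of compound 1. Among the measured compounds shown here, with only three compounds, and with compound 2 indistinguishable from compound 1, no ranking of the set can be claimed.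

Compound 4 `O=S(=O)(Nc1ccc(-c2nc3cc(NS(=O)(=O)c4ccc(Cl)s4)ccc3o2)cc1)c1ccc(Cl)c(C(F)(F)F)c1` has not yet been measured in this assay. It differs from compound 1 in a single place: 4-chloro-3-(trifluoromethyl)phenyl in place of 5-chlorothiophen-2-yl on a sulfonyl sulfur. The other sulfonyl group of compound 1 remains unchanged. For the measured compounds named here, no measured pair shows the effect of this change, so no step of known size can be drawn on.

The account therefore rests on the spread of the three measured compounds, which spans little more than the scatter. Compound 4 is expected to stay close to compound 1, with a step of a 1.4-fold lower number from compound 1 to compound 4 (0.14 log units; within the scatter) not clearly beyond the scatter. The estimate for compound 4 is 30000 nM, with a range from 12000 nM to 70000 nM.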

Compound 4, half-maximal cytotoxic concentration: 34000 nM
Estimate against measurement, compound 4: 1.1-fold (0.05 log units) below, and the stated range covers the measured number.
By their numbers in this assay, from the lowest: compounds 3, 2, 4 and 1 (each within the scatter of the next, the first and the last beyond it).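

Among the compounds shown here, this result gives the first step in the set that can be read at a single place: in this assay, putting 4-chloro-3-(trifluoromethyl)phenyl in place of 5-chlorothiophen-2-yl on a sulfonyl sulfur gives a 1.2-fold lower number from compound 1 to compound 4 (0.08 log units; within the scatter), which lies within the scatter, so the two compounds cannot be told apart. At this place, then, a six-membered aromatic ring of carbon only, bearing chlorine and trifluoromethyl, can stand in for a five-membered aromatic ring with 1 hetero atom without a step beyond the scatter, something the three earlier compounds, which differ in more than one place, could not show. No available evidence bears on why the step is this small.

The compounds shown leave open whether the same replacement on the other sulfonyl group of compound 1, or on both together, would also stay within the scatter. They also leave open whether a group of another kind in this place, such as a carboxylic acid or an amine, would move the number in this assay beyond the scatter.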